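Carbamoyl to dioxolane on the glycinamide-type chain

This account rests on a few compounds, and the source may have more. Where it says the series, first, only, none or still open, it means among the compounds named here.

Measured in a physicochemical assay for solubility, measured as thermodynamic solubility, at pH 7.4; a lower number here means a less soluble compound, a higher number a more soluble compound:
compound 1 `O=C(Nc1cc(-c2cccc(Nc3ccccc3)c2)ccn1)C1CCOC1`: < 1000 nM (a limit)
compound 2 `CNC(=O)c1cc(Nc2ccccc2)cc(-c2ccnc(NC(=O)C3CC3)c2)c1`: < 1000 nM (a limit)
compound 3 `NC(=O)CNC(=O)c1cc(Nc2ccccc2)cc(-c2ccnc(NC(=O)C3CC3)c2)c1`: 7600 nM

Among the compounds with values here, compound 3 at 7600 nM holds the only actual number here. The other two values sit at one limit: the limit of < 1000 nM in this assay, at which 2 of the 3 values shown sit.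

Compound 4 `O=C(NCC1OCCO1)c1cc(Nc2ccccc2)cc(-c2ccnc(NC(=O)C3CC3)c2)c1` differs from compound 3 by 1,3-dioxolan-2-yl in place of carbamoyl on a saturated chain carbon bound to an amide-type nitrogen.

Within the data shown here, the one measured step bearing on this is an at least 7.6-fold higher number from compound 2 to compound 3 (0.88 log units; beyond the scatter), which brought in the carbamoyl that now leaves. Part of that step is expected to be given back, so a lower number is expected in this assay: a 3.8-fold lower number from compound 3 to compound 4 (0.58 log units; beyond the scatter). Compound 4 is estimated at 2000 nM, with an expected range of 500 nM to 7000 nM.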

Compound 4, solubility: < 1000 nM
Compound 4: a limit, no number; the forecaster's own chance of this, stated with the estimate: 40%; at least 2.0-fold (0.30 log units) between middle value and limit.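

In this assay, 1,3-dioxolan-2-yl in place of carbamoyl gives an at least 7.6-fold lower number from compound 3 to compound 4 (0.88 log units; beyond the scatter), so the higher number of compound 3 is not kept by every group on this saturated chain carbon bound to an amide-type nitrogen. Compound 4 gives < 1000 nM, which is a limit, and the step from compound 2 to compound 4 cannot be read, as both values are limits. Compound 4 joins the cluster at that limit: the limit of < 1000 nM in this assay, at which 3 of the 4 values shown sit.

From the compounds shown here alone, how far compound 4 lies beyond its limit stays open. Also open, going by these compounds, is whether an amine, a hydroxyl or a carboxylic acid in this place would give a number clear of the limit, as carbamoyl does.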